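The source may hold more compounds than are shown below. What is called first, only, known or untested is meant among the compounds shown, and "the series" means these compounds.

Compound 1 `CC(C)NC(=S)NC1CC(C)(C)Oc2ccc(Cl)cc21` gives 91000 nM in a functional assay on T98G cells (Homo sapiens) for inhibition, read by MTT assay, with a stated time of 72 h; a higher number here means a weaker inhibitor, a lower number a stronger inhibitor.
Compound 2 `CC1(C)CC(NC(=S)Nc2ccc([N+](=O)[O-])cc2)c2cc(Br)ccc2O1` gives 5000 nM in this assay.
Compound 3 `CC1(C)CC(NC(=S)Nc2ccc(C#N)cc2)c2cc(Cl)ccc2O1` gives 10000 nM in this assay.

Among these three numbers compound 3 stands second highest. Its nearest neighbour is compound 2, whose value sits within the usual scatter of that of compound 3, so no order between the two can be claimed. Among the compounds with values here, compound 1 lies furthest away, and the step of a 9.1-fold lower number from compound 1 to compound 3 (0.96 log units; beyond the scatter) is the only single-point change that has been measured; it is beyond the scatter, though only modest in size.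

Compound 4 `CC1(C)CC(NC(=S)Nc2ccc(C#N)cc2)c2cc(Br)ccc2O1` differs from compound 3 in one place: bromo in place of chloro on an aromatic carbon. Within the data shown here, no measured step isolates this exchange. Among the measured compounds shown here, compound 2 carries bromo at the same place as compound 4, but it also carries a nitro group where compound 3 and compound 4 carry a nitrile, so its comparison with compound 3 shows only two values within the scatter of each other. The step of a 9.1-fold lower number from compound 1 to compound 3 (0.96 log units; beyond the scatter) concerns a different part of the molecule and offers no guide here. With nothing pointing either way, no step beyond the scatter is expected in this assay.

Compound 4 is therefore estimated at 9000 nM in this assay, with a range from 3500 nM to 23000 nM. The expected step is a 1.1-fold lower number from compound 3 to compound 4 (0.05 log units; within the scatter).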

Compound 4, half-maximal inhibitory concentration: 24000 nM
Compound 4: the middle estimate sits 2.7-fold (0.43 log units) below what was measured; the measured number lies above the stated range.
By their numbers in this assay, from the lowest: compounds 2 and 3 (each within the scatter of the next); then compound 4; then compound 1.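

In this assay, within the data shown here, the halogen on the aromatic carbon proves not to be interchangeable: a 2.4-fold higher number from compound 3 to compound 4 (0.38 log units; beyond the scatter) is the first clean reading of this exchange, a modest step but one beyond the scatter, with the nitrile held constant. With bromo held constant, a 4.8-fold higher number from compound 2 to compound 4 (0.68 log units; beyond the scatter) isolates the other exchange, cyano in place of nitro, and shows that the closeness of the values of compound 2 and compound 3 does not mean that these two places have no influence, since that pair differs in both places and the two exchanges appear to pull in opposite directions. No measured evidence is available to explain either step.

The compounds shown leave open how a fluoro or iodo group, or a plain hydrogen, would behave at the halogen position, and so whether the numbers follow any trend across the halogens. They also leave open whether the bromo-for-chloro step keeps its size alongside a nitro group, or what an amine or a carboxylic acid would do in place of the nitrile.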